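The source may hold more compounds than are shown below. What is called first, only, known or untested is meant among the compounds shown, and "the series" means these compounds.

Working notes on the series. The shared core is carried by compound 1 `COc1ccccc1/C=c1/[nH]c(=O)/c(=C\c2cccc(Cl)c2Cl)[nH]c1=O`, compound 2 `C=CCn1c(=O)/c(=C\c2cccc(F)c2)[nH]c(=O)/c1=C\c1ccccc1OC`, compound 3 `C=CCn1c(=O)/c(=C\c2cc(Br)ccc2F)[nH]c(=O)/c1=C\c1ccccc1OC` and the still unmeasured compound 4 `C=CCn1c(=O)/c(=C\c2ccccc2C(F)(F)F)[nH]c(=O)/c1=C\c1ccccc1OC`. In a functional assay on MOLT-4 cells (Homo sapiens) for cytotoxicity, read by CCK-8 assay, with a stated time of 72 h (a lower number here means a stronger inhibitor, a higher number a weaker inhibitor), compound 1 is recorded as "not determined" (no result reported), so it contributes no number. In this assay compound 2 gives 6500 nM. In this assay compound 3 gives 12900 nM. Compound 3 thus carries the higher of the two numbers available, but the step of a 2.0-fold higher number from compound 2 to compound 3 (0.30 log units; within the scatter) is within the scatter, so compound 2 and compound 3 cannot be separated on these data.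

The change from compound 3 to compound 4 is 2-(trifluoromethyl)phenyl in place of 5-bromo-2-fluorophenyl on a double-bonded chain carbon bound to an aromatic carbon. Within the data shown here, the only measured step that touches the same place is a 2.0-fold higher number from compound 2 to compound 3 (0.30 log units; within the scatter), an exchange of one substituted phenyl ring for another that stayed within the scatter. Among the measured compounds shown here, the change to compound 4 is again an exchange of the substitution pattern on the phenyl ring at that place, and nothing measured so far gives a direction for it; the expectation is therefore a step no larger than the scatter, in either direction. The step expected is a 1.3-fold lower number from compound 3 to compound 4 (0.11 log units; within the scatter). In this assay compound 4 is estimated at 10000 nM, with a range from 3000 nM to 35000 nM.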

Compound 4, half-maximal inhibitory concentration: 4400 nM
Compound 4: middle estimate off by 2.3-fold (0.36 log units), on the high side; the measured number falls inside the stated range.
By their numbers in this assay, from the lowest: compounds 4, 2 and 3 (each within the scatter of the next, the first and the last beyond it).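

In this assay, among these compounds, the exchange on a double-bonded chain carbon bound to an aromatic carbon now gives the first step beyond the scatter (a 2.9-fold lower number from compound 3 to compound 4 (0.47 log units; beyond the scatter)), though a modest one, so the phenyl substitution at this place can shift the number. That separation holds only for this pair: compound 2 cannot be separated from compound 4 (a 1.5-fold lower number from compound 2 to compound 4 (0.17 log units; within the scatter)), and it also could not be separated from compound 3 (a 2.0-fold higher number from compound 2 to compound 3 (0.30 log units; within the scatter)), so the three compounds form a narrow run rather than a clear order, with only its two ends apart. Nothing available bears on why 2-(trifluoromethyl)phenyl and 5-bromo-2-fluorophenyl differ here.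

Open, on these data alone, is whether the step comes from the entering trifluoromethyl or from the leaving bromine and fluorine, since these changed together, and whether a phenyl ring carrying an amine or a carboxylic acid at this place would move the number further. As far as these compounds go, compound 1 gives no number, so any step to it cannot be read, and the effect of its other substituted phenyl ring and of the free amide hydrogen remains unknown.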